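The compounds below may be only part of what the source reports. "The series", "measured", "known", "first", "only" and "open" are said of these compounds alone.

Compound 1, with the structure `Cc1c(C(=O)Nc2c(F)cc(-c3cccc(F)c3)cc2F)nc2ccc(C(F)(F)F)cc2c1O`, was examined in a functional assay on A-375 cells (Homo sapiens) for antiproliferative activity, read by MTT assay, with a stated time of 24 h, tested at 0.05 ug/mL (on this read-out higher numbers stand for a stronger effect at the one concentration tested and lower numbers for a weaker effect), where compound 1 gives 3.47%. Compound 3, `Cc1c(C(=O)Nc2c(F)cc(-c3cccc(F)c3)cc2F)nc2ccc(C(F)(F)F)cc2c1C(=O)O`, shares the core of compound 1 and differs from it in one place only, (carboxy in place of hydroxy on an aromatic carbon). In this assay compound 3 gives 1.04%, so that the step of a number 2.4 percentage points lower from compound 1 to compound 3 (within the scatter) lies within the scatter and cannot be read as a real movement in either direction.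

Compound 2, `COc1ccc2nc(C(=O)Nc3ccc(-c4ccccc4)cc3)c(C)c(O)c2c1`, is built on a different core; the difference between the core of compound 2 and that of compound 1 is not broken down here. In this assay compound 2 gives 1.98%, a number that sits within the scatter of both compound 1 and compound 3.

Compound 4, `COc1ccc2nc(C(=O)Nc3ccc(-c4ccccc4)cc3)c(C)c(C(=O)O)c2c1`, stands to compound 2 as compound 3 stands to compound 1: carboxy in place of hydroxy on an aromatic carbon. The surroundings of the place are described in the same words for both pairs, so this is the same change made on a second core. Among the compounds with values here, because the only measured instance of this change, a number 2.4 percentage points lower from compound 1 to compound 3 (within the scatter), stayed within the scatter, compound 4 is expected to stay close to compound 2, with an expected step of a number 1 percentage points lower from compound 2 to compound 4 (within the scatter). On that basis compound 4 is estimated to give 1% in this assay, with an expected range from -4% to 6%.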

Compound 4, a percentage reported as inhibition, at one concentration (the size of the read-out at that concentration, not a potency): 1.26%
Compound 4: middle estimate off by 0.3 percentage points, on the low side; the range from low to high includes it.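

Carrying carboxy in place of hydroxy over to the second core gives, in this assay, a number 0.7 percentage points lower from compound 2 to compound 4 (within the scatter), so the change stays within the scatter here as well. Set beside the earlier step, the new one shows that the change reads alike on the two cores: the same change on two cores in this assay, a number 2.4 percentage points lower (within the scatter) from compound 1 to compound 3 and a number 0.7 percentage points lower (within the scatter) from compound 2 to compound 4, 1.7 percentage points apart, within the scatter of two such steps. Within the data shown here, this agreement is only between two steps that cannot be read as real movement in either direction, so it does not show that a real effect of the change carries from one core to another, and with readings taken at one concentration and only two cores, it gives neither a statement on potency nor a rule for the series.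

The compounds shown leave open whether any group at this place, opposite the ring nitrogen, moves the read-out beyond the scatter, for example an amine or a methyl ester in place of the hydroxy or the carboxy. They also leave open whether the same change would read alike on a third core, or on these two cores at another concentration.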